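Triazene series on L1210: hydroxyethyl to allyl at the amine

The source may report more compounds than this note shows. Statements on the series, on what has been measured and on what is new or still open speak of the compounds shown alone.

Going by the values given here, three aryltriazenes carry numbers so far. Compound 1 `CN(CCO)/N=N/c1ccccc1C(N)=O` gives 3.07 in a functional assay on L1210 cells (Mus musculus) for antiproliferative activity; a higher number here means a more potent compound, by a factor of ten per unit of this negative logarithm, a lower number a less potent compound. Compound 2 `COc1ccc(/N=N/N(C)C(=O)c2ccccc2)cc1` gives 3.05 in this assay, and compound 3 `CN(C)/N=N/c1cc(C#N)cc(C#N)c1` gives 2.78. Compound 1 holds the highest of the three figures, but compound 2 sits within the scatter of it, and so does compound 3, so the three cannot be ranked against each other on these numbers. Among the compounds with values here, no two of them differ in a single place, so no measured step exists yet.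

Compound 4 `C=CCN(C)/N=N/c1ccccc1C(N)=O` keeps the core of compound 1 and changes only the chain on the amine nitrogen: vinyl in place of hydroxymethyl on a saturated chain carbon bound to an amine nitrogen. The loss of the hydrogen-bond donor and acceptor of the hydroxymethyl is the whole of the change. Within the data shown here, nothing measured here speaks to its effect, and the three numbers known are all close to one another.

The step of a number 0.13 log units higher from compound 1 to compound 4 (within the scatter) is therefore expected to be small, with a slight lean upward rather than a loss. Compound 4 is estimated at 3.2, within a range from 2.7 to 3.7.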

Compound 4, logarithm of the reciprocal of the active concentration, log(1/C): 3.43
Estimate against measurement, compound 4: 0.23 log units below, within the range that was stated.
By their numbers in this assay, from the lowest: compounds 3, 2 and 1 (each within the scatter of the next); then compound 4.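

In this assay the series now has its first measured step, with a number 0.36 log units higher from compound 1 to compound 4 (beyond the scatter) for the change from (2-hydroxyethyl)(methyl)amino to allyl(methyl)amino while the rest of the core of compound 1 stays fixed. The number at this position therefore moves with the chain on the amine nitrogen, and the hydroxymethyl is not needed to hold it: vinyl, which has 0 hydrogen-bond donors and 0 hydrogen-bond acceptors, stands in its place with a modest gain rather than a loss. No measurement on hand accounts for the step, and this single pair cannot separate the departure of the hydroxymethyl from the arrival of the vinyl.

Open, on these data alone, is whether a saturated propyl chain in place of allyl would hold the gain, which would show how much depends on the double bond, and whether a longer chain, an amine or a carboxylic acid at the end of the chain would raise or lower the number. Also open, as far as these compounds go, is whether the change from 2-hydroxyethyl to allyl would give a step of similar size on a different core.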